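From a pyridyl amide to a cyclohexyl amide

The compounds below may be only part of what the source reports. "The series", "measured", "known", "first", "only" and "open" are said of these compounds alone.

Compound 3 `Cc1cccc(Cn2c(CN3CCN(C(=O)c4ccncc4)CC3)nc3ccccc32)c1` gives 20.6% in an assay on isolated protein for inhibition of aldehyde dehydrogenase 1A1 (Homo sapiens), read by spectrophotometry, tested at 10 uM (on this read-out lower numbers stand for less inhibition and higher numbers for more inhibition at the one concentration tested (going by the name of the read-out)), the lowest of the three numbers measured. Compound 1 `CCc1ccc(C(=O)N2CCN(Cc3nc4ccccc4n3Cc3cccc(C)c3)CC2)cc1` gives 67% in this assay, and compound 2 `Cc1cccc(Cn2c(CN3CCN(C(=O)CC(C)C)CC3)nc3ccccc32)c1` gives 71.4%; these two lie within the scatter of each other, a number 4.4 percentage points higher from compound 1 to compound 2 (within the scatter). Compound 4 `Cc1cccc(Cn2c(CN3CCN(C(=O)C4CCCCC4)CC3)nc3ccccc32)c1` differs from compound 3 by cyclohexyl in place of pyridin-4-yl on a carbonyl carbon. Among the compounds with values here, two measured steps bear on this change: a number 46.4 percentage points lower from compound 1 to compound 3 (beyond the scatter) and a number 50.8 percentage points lower from compound 2 to compound 3 (beyond the scatter), both large falls when 4-ethylphenyl or isobutyl gives way to pyridin-4-yl on that carbonyl carbon. The step to compound 4 runs the other way, with pyridin-4-yl leaving, so a large rise beyond the scatter is expected, a number 44.4 percentage points higher from compound 3 to compound 4 (beyond the scatter). Compound 4 is therefore estimated at 65%, between 42% and 85%.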

Compound 4, a percentage reported as inhibition, at one concentration (the size of the read-out at that concentration, not a potency): 31.9%
Beside the measured number, compound 4's estimate is 33.1 percentage points above it; measured number below the stated range.
By their numbers in this assay, from the lowest: compound 3; then compound 4; then compounds 1 and 2 (each within the scatter of the next).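

In this assay the departure of pyridin-4-yl does not by itself restore the read-out, since a number 11.3 percentage points higher from compound 3 to compound 4 (beyond the scatter) is only a modest rise. Cyclohexyl, a non-aromatic ring of carbon only, stays well short of the other two groups, with a number 39.5 percentage points lower from compound 2 to compound 4 (beyond the scatter) and a number 35.1 percentage points lower from compound 1 to compound 4 (beyond the scatter) showing that the high values at this carbonyl carbon do not extend to every group lacking a ring nitrogen. Nothing measured here explains this order. On these data alone, whether cyclopropyl, unsubstituted phenyl or a longer chain on this carbonyl carbon would stand with compound 4 or with compounds 1 and 2 remains open.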